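Working notes: from 4-fluorophenyl to 4-fluorobenzyl

The source may report more compounds than this note shows. Statements on the series, on what has been measured and on what is new or still open speak of the compounds shown alone.

For the measured compounds named here, compound 1 `Fc1ccc(CCCN2CCC(c3ccc(F)cc3)CC2)cc1` holds the only actual number so far: in a functional assay (membranes, striatum) for inhibition, with Rattus norvegicus as the target (a lower number here means a stronger inhibitor, a higher number a weaker inhibitor), compound 1 gives 1860 nM. Compound 2 `Fc1ccc(CN2CCC(c3ccc(F)cc3)CC2)cc1` reads > 10000 nM, which is a limit of the assay and not a number. Compound 3 `Fc1ccc(CCCCN2CCC(c3ccc(F)cc3)CC2)cc1` carries 4-fluorobenzyl in place of 4-fluorophenyl on a saturated chain carbon, three bonds along the chain from an amine nitrogen in a ring. Going by the values given here, no measured step covers this change, so the expectation in this assay is anchored on compound 1 at 1860 nM and stays cautious. A modest move toward stronger inhibition is expected, and it may not clear the usual scatter: the expected change is a 1.9-fold lower number from compound 1 to compound 3 (0.27 log units; within the scatter). For compound 3 the estimated value is 1000 nM, with an expected range of 300 nM to 3500 nM.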

Compound 3, inhibition constant: 2540 nM
The estimate for compound 3 lay 2.5-fold (0.40 log units) below the measured number, within the range that was stated.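

In this assay, 4-fluorobenzyl in place of 4-fluorophenyl on a saturated chain carbon, three bonds along the chain from an amine nitrogen in a ring, gives a 1.4-fold higher number from compound 1 to compound 3 (0.14 log units; within the scatter). This position therefore accepts the exchange without a difference that can be separated from assay noise, and neither compound can be called the stronger inhibitor. For the compounds shown here, what the earlier compounds could not show is that these two groups read alike here, both with a real number in this assay.

From the compounds shown here alone, compound 2 stands as a limit and not a number, so steps to it cannot be read: the limit of > 10000 nM in this assay, at which 1 of the 3 values shown sits. Still open is how a longer chain, or an amine or a carboxylic acid in place of the terminal 4-fluorobenzyl, would read in this assay.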